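Fluoro for methoxy on an imidazopyrazine-linked phenyl ring

The source may hold more compounds than are shown below. What is called first, only, known or untested is meant among the compounds shown, and "the series" means these compounds.

Compound 1 `Clc1ccc(-c2cn3ccnc3c(-c3ccc4ncn(C5CCCCC5)c4c3)n2)cc1` and compound 2 `COc1ccccc1-c1cn2ccnc2c(-c2ccc3ncn(C4CCCCC4)c3c2)n1` share a core and differ only in the aryl group. In a functional assay on OVCAR-3 cells (Homo sapiens) for inhibition, read by sulforhodamine B assay, with a stated time of 48 h, tested at 10 uM (on this read-out lower numbers stand for less inhibition and higher numbers for more inhibition at the one concentration tested (going by the name of the read-out)), compound 1 gives 10.9%, and compound 2 gives 6.57%; the step of a number 4.3 percentage points lower from compound 1 to compound 2 (within the scatter) keeps both within the scatter, so compound 2 stands alongside compound 1 rather than apart from it. Compound 3 `Fc1ccccc1-c1cn2ccnc2c(-c2ccc3ncn(C4CCCCC4)c3c2)n1` carries the change (fluoro in place of methoxy on an aromatic carbon). Among the measured compounds shown here, the only step that bears on this, from compound 1 to compound 2, also swapped the aryl substituent and stayed within the scatter, so no step beyond the scatter is expected in this assay. Compound 3 is therefore estimated at 9%, between 0% and 25%, a shift of a number 2.4 percentage points higher from compound 2 to compound 3 (within the scatter) that is expected to be small.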

Compound 3, a percentage reported as inhibition, at one concentration (the size of the read-out at that concentration, not a potency): 0.17%
The estimate for compound 3 lay 8.8 percentage points above the measured number, within the range that was stated.
By their numbers in this assay, from the lowest: compounds 3, 2 and 1 (each within the scatter of the next, the first and the last beyond it).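

Fluoro in place of methoxy, ortho to a large group, gives a number 6.4 percentage points lower from compound 2 to compound 3 (within the scatter), so in this assay this change does not set compound 3 apart from compound 2. Among the compounds shown here, the 2-fluorophenyl in place of 4-chlorophenyl gives a number 10.7 percentage points lower from compound 1 to compound 3 (beyond the scatter), the first step in this set beyond the scatter, though only a modest one. Nothing available explains either step.

That last step changes both the halogen and its place on the ring. A 2-chlorophenyl group would be needed to tell the two apart. On these data alone, whether an amine or a carboxylic acid on this ring would stand beyond the scatter from compound 2 also remains open.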